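The source may hold more compounds than are shown below. What is called first, only, known or untested is meant among the compounds shown, and "the series" means these compounds.

Working notes on the series in a functional assay on HeLa cells for agonist activity at 5-hydroxytryptamine receptor 6 (Homo sapiens), read by cAMP accumulation and immunoassay; a higher number here means a larger maximal response, a lower number a smaller maximal response.

Compound 1 `CN1CCC(n2cc(S(=O)(=O)c3ccccc3)c3cccnc32)C1` gives 61%. Compound 2 `CN1CCC(n2cc(S(=O)(=O)c3cccc(F)c3)c3cccnc32)C1` gives 54%. Compound 3 `O=S(=O)(c1ccccc1Cl)c1cn(C2CCCNC2)c2ncccc12` gives 84%. Among these three, compound 2 holds the lowest number: the nearest is compound 1, and the step of a number 7 percentage points lower from compound 1 to compound 2 (within the scatter) leaves the two indistinguishable; the furthest is compound 3, whose number stands higher by a margin beyond the scatter, though compound 3 differs from compound 2 in more than one place, so only the two values themselves can be compared.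

Compound 4 `CN1CCCC(n2cc(S(=O)(=O)c3cccc(F)c3)c3cccnc32)C1` has not yet been measured. It differs from compound 2 as follows: 1-methylpiperidin-3-yl in place of 1-methylpyrrolidin-3-yl on an aromatic nitrogen. Within the data shown here, no measured pair isolates this ring enlargement; the only measured single step, from compound 1 to compound 2, concerns a fluoro substituent and stays within the scatter. Among the measured compounds shown here, with no step bearing directly on the change, no movement beyond the scatter is expected. Compound 4 is therefore estimated at 60%, within 45% to 78%, a step of a number 6 percentage points higher from compound 2 to compound 4 (within the scatter) that is expected to stay within the scatter.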

Compound 4, largest response reached (Emax), in percent of the reference or control that the assay uses: 75%
Compound 4: middle estimate off by 15 percentage points, on the low side; low and high end bracket the measured number.
By their numbers in this assay, from the lowest: compounds 2 and 1 (each within the scatter of the next); then compounds 4 and 3 (each within the scatter of the next).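

In this assay, among these compounds, the step of a number 21 percentage points higher from compound 2 to compound 4 (beyond the scatter) is the first single change to pass beyond the scatter, and it comes from 1-methylpiperidin-3-yl in place of 1-methylpyrrolidin-3-yl on an aromatic nitrogen. Among the compounds shown here, the maximal response therefore moves with the ring on this nitrogen, whereas the one earlier single step, the fluoro change on the aromatic carbon, stayed within the scatter. No available data bear on why the six-membered ring gives the larger response.

Going by these compounds, this reading rests on one pair, so it remains open whether the same ring change gives a similar step with the unsubstituted aromatic ring of compound 1 or with other substituents there. Also open, on these data alone, is how an open-chain group such as 2-aminoethyl, or a seven-membered azepanyl ring, would read on this nitrogen.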